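A few compounds are considered here, and "the series" means these few. Any claim that something is new, unique, unknown or untested is made for them only; others in the source may bear on it.

Measured so far in a functional assay on NCI-H1975 cells (Homo sapiens) for inhibition, read by MTT assay, with a stated time of 72 h; a lower number here means a stronger inhibitor, a higher number a weaker inhibitor:
- compound 1 `FC(F)(F)c1ccc(CSc2nc(Sc3ncccn3)cc(C(F)(F)F)n2)cc1` gives 14000 nM
- compound 2 `FC(F)(F)c1ccc(CSc2nc(Sc3nnnn3-c3ccccc3)cc(C(F)(F)F)n2)cc1` gives 24300 nM
- compound 3 `Cc1nnc(Sc2cc(C(F)(F)F)nc(SCc3ccc(C(F)(F)F)cc3)n2)s1` gives 3060 nM

Compound 3 has the lowest number of the three, and its gaps to both others lie beyond the scatter. Compound 4 `FC(F)(F)c1ccc(CSc2nc(Sc3ncc(-c4ccncc4)s3)cc(C(F)(F)F)n2)cc1` has not yet been measured. It carries 5-(pyridin-4-yl)-1,3-thiazol-2-yl in place of 5-methyl-1,3,4-thiadiazol-2-yl on a sulfur and is otherwise the same. Within the data shown here, two measured steps bear on this swap, as each changed the group on that same sulfur: a 4.6-fold lower number from compound 1 to compound 3 (0.66 log units; beyond the scatter) and a 7.9-fold lower number from compound 2 to compound 3 (0.90 log units; beyond the scatter). Both arrived at the group that compound 4 gives up, and both lowered the number by a modest amount. Among the measured compounds shown here, a modest rise in this assay is therefore expected on leaving it, although no measured compound carries the entering group, so this expectation is loose. The expected change is a 2.0-fold higher number from compound 3 to compound 4 (0.29 log units; within the scatter). For compound 4 the estimated value is 6000 nM, with an expected range from 1800 nM to 20000 nM.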

Compound 4, half-maximal inhibitory concentration: 16700 nM
Estimate against measurement, compound 4: 2.8-fold (0.44 log units) below; low and high end bracket the measured number.
By their numbers in this assay, from the lowest: compound 3; then compounds 1, 4 and 2 (each within the scatter of the next).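

Replacing 5-methyl-1,3,4-thiadiazol-2-yl on this sulfur with the larger 5-(pyridin-4-yl)-1,3-thiazol-2-yl does not hold the number reached by compound 3 in this assay (a 5.5-fold higher number from compound 3 to compound 4 (0.74 log units; beyond the scatter)). Compound 4 instead falls in with the two other compounds (a 1.5-fold lower number from compound 2 to compound 4 (0.16 log units; within the scatter); a 1.2-fold higher number from compound 1 to compound 4 (0.08 log units; within the scatter)). Compounds 1, 2 and 4 therefore carry three different groups on this sulfur yet give numbers within the scatter of one another, and compound 3 alone stands apart from all of them.

As far as these compounds go, it remains open whether the methyl of the 5-methyl-1,3,4-thiadiazol-2-yl group matters, and how an amine or an ethyl chain in place of that methyl would read. Nothing available here explains why compound 3 stands apart.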